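A few compounds are considered here, and "the series" means these few. Any claim that something is new, unique, unknown or untested is made for them only; others in the source may bear on it.

Series notes. The shared core of compound 1 `O=c1ccc2cc(OCc3cn(-c4ccccc4Cl)nn3)ccc2o1` is kept throughout; the compounds differ only in the aryl group carried on the aromatic nitrogen of the five-membered ring. In a functional assay on A549 cells (Homo sapiens) for cytotoxicity, read by MTT assay, with a stated time of 48 h (on this read-out lower numbers stand for stronger inhibition and higher numbers for weaker inhibition), compound 1 gives 17100 nM, a weak result. Among the measured compounds shown here, compound 2 `O=c1ccc2cc(OCc3cn(-c4cccc([N+](=O)[O-])c4)nn3)ccc2o1` and compound 3 `O=c1ccc2cc(OCc3cn(-c4ccc(Cl)c(Cl)c4)nn3)ccc2o1` were run in this assay but neither returned a single number: compound 2 gives "not determined" (no result reported), and compound 3 gives "not determined" (no result reported), so compound 3 stands without a value of its own, and no step between measured compounds can be drawn; compound 1 is the only anchor.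

Compound 4 `N#Cc1ccccc1-n1cc(COc2ccc3oc(=O)ccc3c2)nn1` is the next step from compound 3: 2-cyanophenyl in place of 3,4-dichlorophenyl on an aromatic nitrogen. For the measured compounds named here, with no measured step to rest on, the size and direction of the change from compound 3 to compound 4 cannot be stated beyond the scatter. Expectation rests on compound 1 alone, whose result of 17100 nM is the one number in the series. Compound 4 is therefore expected to give about 20000 nM in this assay, estimated within 5000 nM to 80000 nM, with a real chance that only a limit is reported, as happened for compound 2 and compound 3.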

Compound 4, half-maximal inhibitory concentration: 12600 nM
Compound 4: the middle estimate sits 1.6-fold (0.20 log units) above what was measured, within the range that was stated.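

Among the compounds shown here, the first readable comparison in this assay is a 1.4-fold lower number from compound 1 to compound 4 (0.13 log units; within the scatter), with cyano in place of chloro on an aromatic carbon, so at this position on the aryl group the two substituents are not separated by the read-out. Steps involving compound 2 or compound 3 cannot be read, as neither compound has a value to compare with compound 4. No measurement available here speaks to the reason for this result.

On these data alone, whether an amine, a methoxy group or a carboxylic acid on the aryl group would shift the number beyond the scatter remains open. Also open, as far as these compounds go, is whether a benzyl group or a longer alkyl chain on the aromatic nitrogen, in place of the aryl ring, would do so.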